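The source may report more compounds than this note shows. Statements on the series, on what has been measured and on what is new or still open speak of the compounds shown alone.

Measured so far in a functional assay on the whole organism with Mus musculus as the target (on this read-out lower numbers stand for an effect already at smaller amounts and higher numbers for an effect only at larger amounts of compound), are two compounds:
- compound 1 `CNC(=O)[C@H](CCSC)NCc1ccc(OCc2ccccc2)cc1` with 239 mg/kg
- compound 2 `C[C@@H](NCc1ccc(OCc2ccccc2Cl)cc1)C(N)=O` with 17.4 mg/kg

Of the two, compound 2 holds the lower number, and its gap to compound 1 lies beyond the usual scatter. Compound 3 `C[C@@H](NCc1ccc(OCc2ccsc2)cc1)C(N)=O` carries thiophen-3-yl in place of 2-chlorophenyl on a saturated chain carbon bound to an oxygen on an aromatic ring. For the measured compounds named here, no measured pair shows this change, so a step within the scatter in this assay is expected, with no firm direction. The estimate amounts to a 1.3-fold higher number from compound 2 to compound 3 (0.10 log units; within the scatter) as an expected move. Compound 3 is estimated at 22 mg/kg with an expected range of 9 mg/kg to 55 mg/kg.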

Compound 3, dose for half-maximal effect: 114 mg/kg
Beside the measured number, compound 3's estimate is 5.2-fold (0.71 log units) below it; the whole stated range lies below it.
By their numbers in this assay, from the lowest: compound 2; then compound 3; then compound 1.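

In this assay, thiophen-3-yl in place of 2-chlorophenyl on a saturated chain carbon bound to an oxygen on an aromatic ring gives a 6.6-fold higher number from compound 2 to compound 3 (0.82 log units; beyond the scatter) on an otherwise unchanged core. This position therefore responds to the group it carries, and the five-membered sulfur ring is not interchangeable here with 2-chlorophenyl. Nothing measured explains the step. The compounds shown leave open whether the chlorine or the ring itself drives the difference. A pyridinyl ring, or fluorine in place of the chlorine, could begin to separate the two.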